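The source may report more compounds than this note shows. Statements on the series, on what has been measured and on what is new or still open speak of the compounds shown alone.

Measured in an ADME assay on MRC5 cells (Homo sapiens) for inhibition, with a stated time of 72 h; on this read-out lower numbers stand for an effect already at smaller amounts and higher numbers for an effect only at larger amounts of compound:
- Compound 1 `COc1cccc(OC)c1C(=O)Nc1c[nH]nc1C(=O)NC1CC2CCC1C2`: > 50000 nM, a limit of the assay
- Compound 2 `COc1cccc(OC)c1C(=O)Nc1c[nH]nc1C(=O)O`: > 50000 nM, a limit of the assay
- Compound 3 `COc1cccc(OC)c1C(=O)Nc1c[nH]nc1C(=O)NCc1ccccc1`: 50000 nM

Going by the values given here, compound 3 holds the only true number of the three. Compound 1 and compound 2 both stop at a limit, (the limit of > 50000 nM in this assay, at which 2 of the 3 values shown sit).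

Compound 4 `COc1cccc(OC)c1C(=O)Nc1c[nH]nc1C(=O)NC1CCCCCC1` carries cycloheptyl in place of benzyl on an amide-type nitrogen.

The closest measured change is a number no higher from compound 1 to compound 3 (the limit leaves the size open), which also swaps the group on that nitrogen. The others are a number no higher from compound 2 to compound 3 (the limit leaves the size open) and a step that the two limits leave unreadable from compound 1 to compound 2. None of these has a readable size, so nothing points to a real shift.

The expected result in this assay is no step beyond the usual scatter: no change at the digits printed from compound 3 to compound 4 (within the scatter). For compound 4 the estimate is 50000 nM, with an expected range from 20000 nM to 100000 nM.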

Compound 4, half-maximal effective concentration: 42000 nM
For compound 4 the middle estimate is 1.2-fold (0.08 log units) above the measured one; the measured number falls inside the stated range.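

In this assay, going by these compounds alone, compound 4 gives the first comparison at this amide-type nitrogen in which both values are true numbers (a 1.2-fold lower number from compound 3 to compound 4 (0.08 log units; within the scatter)). Within the scatter, the aromatic benzyl and the non-aromatic cycloheptyl cannot be told apart here. The steps from the two limit compounds give only floors (an at least 1.1-fold lower number from compound 2 to compound 4 (0.07 log units; that floor lies within the scatter); an at least 1.1-fold lower number from compound 1 to compound 4 (0.07 log units; that floor lies within the scatter)), and neither compound has a true number: the limit of > 50000 nM in this assay, at which 2 of the 4 values shown sit.

As far as these compounds go, what stays open is whether a cycloalkyl with a basic amine on its ring, or a longer chain ending in a carboxylic acid, would read differently on this nitrogen.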